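This account rests on a few compounds, and the source may have more. Where it says the series, first, only, none or still open, it means among the compounds named here.

Measured so far in an assay on HEK293 cells for displacement of a labelled ligand from metabotropic glutamate receptor 5 (Homo sapiens), with a stated time of 2 h; a lower number here means a stronger inhibitor, a higher number a weaker inhibitor: compound 1 `CC(C)N1CCc2nc(C#Cc3cccnc3)ccc2C1=O` gives 19600 nM; compound 2 `CC(C)N1CCc2nc(C#Cc3cccs3)ccc2C1=O` gives 1930 nM; compound 3 `O=C1c2ccc(C#Cc3cccnc3)nc2CCN1C1CCCC1` gives > 32000 nM.

For compound 3 that value is a limit of the assay, not a number (the limit of > 32000 nM in this assay, at which 1 of the 3 values shown sits). Compound 4 `O=C1c2ccc(C#Cc3cccs3)nc2CCN1C1CCCC1` has not yet been measured in this assay.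

The change from compound 1 to compound 2 is thiophen-2-yl in place of pyridin-3-yl on a triple-bonded carbon; it made a step of a 10-fold lower number from compound 1 to compound 2 (1.01 log units; beyond the scatter). The cores of compound 3 and compound 1 differ by cyclopentyl in place of isopropyl on an amide-type nitrogen in a ring, with a step of an at least 1.6-fold higher number from compound 1 to compound 3 (0.21 log units; that floor lies within the scatter). The change from compound 3 to compound 4 is thiophen-2-yl in place of pyridin-3-yl on a triple-bonded carbon, made at the same place, so it is the same change.

Compound 4 is expected to show a step of an at least 6.4-fold lower number from compound 3 to compound 4 (0.80 log units; beyond the scatter), a size that rests on the step of a 10-fold lower number from compound 1 to compound 2 (1.01 log units; beyond the scatter) for the same change, measured from a numeric starting value. For compound 4 the estimate in this assay is 5000 nM, between 1500 nM and 20000 nM.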

Compound 4, inhibition constant: 2840 nM
The estimate for compound 4 lay 1.8-fold (0.25 log units) above the measured number; the range from low to high includes it.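

In this assay, thiophen-2-yl in place of pyridin-3-yl on the cyclopentyl compounds gives a large step, an at least 11-fold lower number from compound 3 to compound 4 (1.05 log units; beyond the scatter), while cyclopentyl in place of isopropyl on the thiophene compounds gives only a small one, a 1.5-fold higher number from compound 2 to compound 4 (0.17 log units; within the scatter). Compound 3 gives > 32000 nM, which is a limit of the assay and not a number. The change therefore carries over in direction on these two cores, but an exact match in size is not shown: the same change on two cores in this assay, a 10-fold lower number (1.01 log units; beyond the scatter) from compound 1 to compound 2 and an at least 11-fold lower number (1.05 log units; beyond the scatter) from compound 3 to compound 4; the limit leaves it open whether they differ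

Two cores are a narrow base for any general rule. Still open, as far as these compounds go, is whether the same change holds with a methyl group or a longer chain on the amide-type nitrogen, and how a phenyl ring on the triple-bonded carbon would compare.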